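Working notes: hydrogen to propyl on the chain carbon

A few compounds are considered here, and "the series" means these few. Any claim that something is new, unique, unknown or untested is made for them only; others in the source may bear on it.

Measured compounds in a functional assay on the whole organism with Mus musculus as the target, in the writhing test; on this read-out higher numbers stand for an effect only at larger amounts of compound and lower numbers for an effect already at smaller amounts:
compound 1 `Cc1cc(=O)oc2c1c(C)nn2C` gives 11.6 mg/kg
compound 2 `CCn1nc(C)c2c(C)cc(=O)oc21` gives 24.9 mg/kg
compound 3 `CCn1nc2oc(=O)cc(C)c2c1C` gives 14.6 mg/kg

Compound 3 stands second highest of the three numbers; its gaps to compound 1 and to compound 2 both lie within the scatter, so the three numbers cannot be ordered with confidence. Compound 4 `CCCCCn1nc2oc(=O)cc(C)c2c1C` differs from compound 3 by propyl in place of hydrogen on a saturated chain carbon, two bonds along the chain from an aromatic nitrogen. For the measured compounds named here, the only measured step of the same kind, a chain lengthened at the same nitrogen, is a 2.1-fold higher number from compound 1 to compound 2 (0.33 log units; beyond the scatter). Lengthening the chain further is therefore expected to move the number in the same direction by a modest amount, about a 1.8-fold higher number from compound 3 to compound 4 (0.25 log units; within the scatter). Compound 4 is accordingly estimated at 26 mg/kg, with a range of 12 mg/kg to 55 mg/kg.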

Compound 4, dose for half-maximal effect: 60.6 mg/kg
Compound 4: the middle estimate sits 2.3-fold (0.37 log units) below what was measured, and the stated range ends below it.
By their numbers in this assay, from the lowest: compounds 1, 3 and 2 (each within the scatter of the next, the first and the last beyond it); then compound 4.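

In this assay, for the compounds shown here, the change from ethyl to pentyl gives a 4.2-fold higher number from compound 3 to compound 4 (0.62 log units; beyond the scatter), the first step beyond the scatter on the core of compound 3. Together with the methyl step on the core of compound 1, it means that both chain extensions shown raise the number, so neither points to a gain from a longer chain at this position. Nothing available explains the size of this step.

Open, from the compounds shown here alone, is how the number behaves with a propyl or butyl chain at this position. Also open, going by these compounds, is whether an amine or a carboxylic acid at the chain end would lower it.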